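Fluoro in place of hydrogen on compound 1

This account rests on a few compounds, and the source may have more. Where it says the series, first, only, none or still open, it means among the compounds named here.

In a functional assay on PC-3 cells (Homo sapiens) for cytotoxicity, read by MTT assay, with a stated time of 72 h (a higher number here means a weaker inhibitor, a lower number a stronger inhibitor), compound 1 (`COc1ccc(-n2ccc(=O)c(C(=O)Nc3ccc(Oc4ccnc5[nH]ccc45)cc3)n2)cc1`) gives > 60000 nM, which is a limit and not a number. Compound 2 (`O=C(Nc1ccc(Oc2ccnc3[nH]ccc23)cc1)c1nn(-c2ccccc2)ccc1=O`) gives 15000 nM in this assay. That measured step, an at least 4.0-fold lower number from compound 1 to compound 2 (0.60 log units; beyond the scatter), is hydrogen in place of methoxy, a different change, so it bears only loosely on compound 3 (`COc1ccc(-n2ccc(=O)c(C(=O)Nc3ccc(Oc4ccnc5[nH]ccc45)c(F)c3)n2)cc1`). Compound 3 carries fluoro in place of hydrogen on an aromatic carbon. No step beyond the scatter is expected in this assay. The expected result is an at least 1.2-fold lower number from compound 1 to compound 3 (0.07 log units; that floor lies within the scatter). Compound 3 is estimated at 50000 nM, with an expected range of 15000 nM to 120000 nM.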

Compound 3, half-maximal inhibitory concentration: 46400 nM
Compound 3: the middle estimate sits 1.1-fold (0.03 log units) above what was measured; the range from low to high includes it.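

In this assay, fluoro in place of hydrogen on an aromatic carbon, ortho to a large group and meta to a large group, gives an at least 1.2-fold lower number from compound 1 to compound 3 (0.11 log units; that floor lies within the scatter). This is the first change shown at this place, and it keeps the methoxy that the earlier step replaced. Compound 1 stands at a limit, so the true size of this step stays unread: the limit of > 60000 nM in this assay, at which 1 of the 3 values shown sits.

On these data alone, whether chloro or an amine on this same aromatic carbon would give a step beyond the scatter remains open. As far as these compounds go, how fluoro at this place would read on compound 2 also remains open.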